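Ethylamino to 4-methylpiperazin-1-yl on the shared core

This account rests on a few compounds, and the source may have more. Where it says the series, first, only, none or still open, it means among the compounds named here.

In a functional assay on NB1 cells (Homo sapiens) for cytotoxicity, read by MTT assay, with a stated time of 3 days (a lower number here means a stronger inhibitor, a higher number a weaker inhibitor), compound 1 `N#Cc1c(O)nc(SCc2nc3ccccc3[nH]2)nc1-c1ccccc1` gives 6.57 nM and compound 3 `N#Cc1c(NC(N)=S)nc(SCc2nc3ccccc3[nH]2)nc1-c1ccccc1` gives 11.9 nM. Compound 2 `CCNc1nc(SCc2nc3ccccc3[nH]2)nc(-c2ccccc2)c1C#N` gives 2.63 nM, the lowest of the three numbers. Compound 4 `CN1CCN(c2nc(SCc3nc4ccccc4[nH]3)nc(-c3ccccc3)c2C#N)CC1` has 4-methylpiperazin-1-yl in place of ethylamino on the aromatic carbon ortho to a cyano group: 4-methylpiperazin-1-yl in place of ethylamino on an aromatic carbon. Two modest measured steps at this carbon bear on the change: a 2.5-fold lower number from compound 1 to compound 2 (0.40 log units; beyond the scatter) and a 4.5-fold higher number from compound 2 to compound 3 (0.66 log units; beyond the scatter). A third, a 1.8-fold higher number from compound 1 to compound 3 (0.26 log units; within the scatter), stays within the scatter. Ethylamino holds the lowest number so far, but no measured compound has a ring at this carbon. A similarly modest rise is therefore expected in this assay, namely a 2.3-fold higher number from compound 2 to compound 4 (0.36 log units; beyond the scatter). Compound 4 is estimated at 6 nM, with an expected range of 2 nM to 18 nM.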

Compound 4, half-maximal inhibitory concentration: 2.4 nM
The estimate for compound 4 lay 2.5-fold (0.40 log units) above the measured number; measured number inside the range.
By their numbers in this assay, from the lowest: compounds 4 and 2 (each within the scatter of the next); then compounds 1 and 3 (each within the scatter of the next).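

In this assay, a ring at this carbon turns out to be compatible with a low number: 4-methylpiperazin-1-yl, with no hydrogen-bond donor, stands level with ethylamino, with a 1.1-fold lower number from compound 2 to compound 4 (0.04 log units; within the scatter). The ring substituent also separates from the other two groups, with a 2.7-fold lower number from compound 1 to compound 4 (0.44 log units; beyond the scatter) and a 5.0-fold lower number from compound 3 to compound 4 (0.70 log units; beyond the scatter). No measurement shown here accounts for these numbers. On these data alone, whether the second ring nitrogen of the piperazine matters stays open. Morpholine or a longer chain such as butylamino at this carbon would bear on that question.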